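A few compounds are considered here, and "the series" means these few. Any claim that something is new, unique, unknown or untested is made for them only; others in the source may bear on it.

In a functional assay on ZR-75-1 cells (Homo sapiens) for cytotoxicity, read by sulforhodamine B assay, with a stated time of 72 h (on this read-out lower numbers stand for an effect already at smaller amounts and higher numbers for an effect only at larger amounts of compound), compound 1 (`CCOc1cccc(-c2cc3occ(C)c3c(=O)o2)c1`) gives 2.2 uM and compound 2 (`Cc1coc2cc(-c3cccc(O)c3)oc(=O)c12`) gives 0.9 uM as the lower of the two numbers. Compound 3 (`Cc1coc2cc(-c3ccc(O)c(O)c3)oc(=O)c12`) differs from compound 2 by hydroxy in place of hydrogen on an aromatic carbon ortho to a hydroxy group and para to a large group. Within the data shown here, the only measured step that bears on this is modest (a 2.4-fold lower number from compound 1 to compound 2 (0.39 log units; beyond the scatter)) and is a different change, so only a similarly modest move to a lower number is expected in this assay (expected: a 1.8-fold lower number from compound 2 to compound 3 (0.26 log units; within the scatter)). For compound 3 the estimated value is 0.5 uM (expected range 0.15 uM to 1.8 uM).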

Compound 3, concentration for half-maximal effect: 1.2 uM
Compound 3: middle estimate off by 2.4-fold (0.38 log units), on the low side; low and high end bracket the measured number.
By their numbers in this assay, from the lowest: compounds 2, 3 and 1 (each within the scatter of the next, the first and the last beyond it).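

In this assay, hydroxy in place of hydrogen on an aromatic carbon, ortho to a hydroxy group and para to a large group, gives a 1.3-fold higher number from compound 2 to compound 3 (0.12 log units; within the scatter) and so leaves the number within the scatter. Unlike the earlier step, which changed the group on the oxygen, this shows that the ring position can carry a hydroxy group without a change beyond the scatter. No measurement available here explains this result. Going by these compounds, whether a methoxy group, an amine or fluorine at this position would behave the same remains open.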